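The compounds below may be only part of what the source reports. "The series", "measured", "known", "first", "only" and "open" are said of these compounds alone.

Measured so far in an assay on CHO cells for displacement of a labelled ligand from adenosine receptor A1 (Homo sapiens), read by scintillation counting, with a stated time of 120 min, tested at 1 uM; a lower number here means less inhibition, a higher number more inhibition at the concentration tested (going by the name of the read-out):
Compound 1 `Cc1nc(NC(=O)c2ccccc2)c2nn(-c3ccccc3)cc2n1` gives 30%.
Compound 2 `Cc1nc(NC(=O)Nc2ccccc2)c2nn(-c3ccccc3)cc2n1` gives 1%.

Going by the values given here, compound 2 stands lowest of the two numbers in this assay; its nearest neighbour is compound 1, and the only measured step, a number 29 percentage points lower from compound 1 to compound 2 (beyond the scatter), separates them. Compound 3 `Cc1nc(NC(=O)c2ccncc2)c2nn(-c3ccccc3)cc2n1` is not yet measured. It differs from compound 2 by pyridin-4-yl in place of anilino on a carbonyl carbon. Among the compounds with values here, the one measured step bears directly on this, since it runs the other way: it turned a carbonyl-bound phenyl into an anilino group and lost a modest amount. Compound 3 turns the anilino group back into a ring bound straight to the carbonyl carbon, now with one ring nitrogen instead of a carbon-only ring. Within the data shown here, no measured pair shows what that ring nitrogen does on its own. A modest rise is therefore expected, roughly undoing the earlier loss, as a number 24 percentage points higher from compound 2 to compound 3 (beyond the scatter). Compound 3 is estimated at 25%, between 5% and 50%.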

Compound 3, a percentage reported as inhibition, at one concentration (the size of the read-out at that concentration, not a potency): 12%
Compound 3: the middle estimate sits 13 percentage points above what was measured, within the range that was stated.
By their numbers in this assay, from the lowest: compound 2; then compound 3; then compound 1.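

Replacing the anilino group with pyridin-4-yl on a carbonyl carbon gives a number 11 percentage points higher from compound 2 to compound 3 (beyond the scatter) in this assay, so this ring bound straight to the carbonyl carbon recovers only part of the value of compound 1. The effect of the ring nitrogen can now be read directly: pyridin-4-yl in place of phenyl gives a number 18 percentage points lower from compound 1 to compound 3 (beyond the scatter), which leaves the carbon-only ring of compound 1 highest of these three compounds. No available evidence explains either step.

From the compounds shown here alone, it remains open whether the lower number with the ring nitrogen would hold for other groups on the carbonyl carbon, such as a short alkyl chain or a saturated amine like piperidine. Whether any such group could exceed the phenyl group of compound 1 is also unresolved.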